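Working notes: methyl for trifluoromethoxy, compound 2 to compound 4

This account rests on a few compounds, and the source may have more. Where it says the series, first, only, none or still open, it means among the compounds named here.

Measured so far in a functional assay on HCT-116 cells (Homo sapiens) for inhibition, read by sulforhodamine B assay, with a stated time of 72 h; on this read-out higher numbers stand for weaker inhibition and lower numbers for stronger inhibition:
compound 1 `CC(c1ccc(-c2ccccc2)c(F)c1)c1nnc2n1N=C(c1ccc(OC(F)(F)F)cc1)CS2` gives 5400 nM
compound 2 `COc1ccc2cc(C(C)c3nnc4n3N=C(c3ccc(OC(F)(F)F)cc3)CS4)ccc2c1` gives 11700 nM
compound 3 `CC(C)Cc1ccc(C(C)c2n[nH]c(=S)n2N)cc1` gives 27400 nM

Compound 2 stands second highest of the three numbers. Its nearest neighbour is compound 1, whose number is lower by a gap beyond the scatter; compound 3 sits furthest away, with a number higher by a gap also beyond the scatter. For the measured compounds named here, the two compounds sharing the core of compound 2 differ only in the group carried on the ethyl-linked aryl part, and no pair of measured compounds differs in a single place, so no measured step is available.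

Compound 4 `COc1ccc2cc(C(C)c3nnc4n3N=C(c3ccc(C)cc3)CS4)ccc2c1` has not been measured in this assay. It differs from compound 2 by methyl in place of trifluoromethoxy on an aromatic carbon, on an aromatic carbon para to a large group; one bond further out this reads 4-(trifluoromethoxy)phenyl to 4-methylphenyl.

Going by the values given here, no measured step covers this change, so the step from compound 2 to compound 4 is expected to stay within the scatter, or at most to run slightly toward a higher number, a 1.3-fold higher number from compound 2 to compound 4 (0.11 log units; within the scatter). For compound 4 the expected value in this assay is 15000 nM, with a range from 5000 nM to 45000 nM.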

Compound 4, half-maximal inhibitory concentration: 10200 nM
For compound 4 the middle estimate is 1.5-fold (0.17 log units) above the measured one; measured number inside the range.
By their numbers in this assay, from the lowest: compounds 1, 4 and 2 (each within the scatter of the next, the first and the last beyond it); then compound 3.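

In this assay the series now has a step that changes one place only, and it reads a 1.1-fold lower number from compound 2 to compound 4 (0.06 log units; within the scatter). On this aromatic carbon, para to a large group, trifluoromethoxy with 5 heavy atoms and 1 hydrogen-bond acceptor can give way to methyl with 1 heavy atom and no hydrogen-bond acceptor, with the read-out staying within the scatter on the core of compound 2. No measurement at hand bears on why the two groups read alike.

On these data alone, whether an amine, a carboxylic acid or a longer alkyl chain on this carbon would also leave the read-out within the scatter stays open. Also open, as far as these compounds go, is whether the same exchange would read alike with the ethyl-linked aryl part of compound 1 in place.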